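This account rests on a few compounds, and the source may have more. Where it says the series, first, only, none or still open, it means among the compounds named here.

Of the compounds shown here, two of a shared core have been measured in a functional assay on DU-145 cells (Homo sapiens) for inhibition, read by MTT assay, with a stated time of 24 h; on this read-out lower numbers stand for stronger inhibition and higher numbers for weaker inhibition. Compound 1 `O=C(O)C1=Cc2ccccc2OC1(OCc1cc(-c2ccc3ccccc3c2)no1)C(F)(F)F` carries a naphthalen-2-yl group on the five-membered aromatic ring, and in this assay compound 1 gives 141000 nM. Compound 2 `O=C(O)C1=Cc2ccccc2OC1(OCc1cc(-c2cccc(C(F)(F)F)c2)no1)C(F)(F)F` carries a 3-(trifluoromethyl)phenyl group in its place, and in this assay compound 2 gives 155000 nM. The step between them, a 1.1-fold higher number from compound 1 to compound 2 (0.04 log units; within the scatter), does not separate the two compounds, so neither can be called the more or the less active of the pair. On the numbers shown, compound 2 holds the highest of the two values, with compound 1 close beside it.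

Compound 3 `COc1ccc(-c2cc(COC3(C(F)(F)F)Oc4ccccc4C=C3C(=O)O)on2)cc1` is the next member of the series and differs from compound 2 in one place: 4-methoxyphenyl in place of 3-(trifluoromethyl)phenyl on an aromatic carbon. Among the measured compounds shown here, the only step that bears on this exchange is the one from compound 1 to compound 2, which stayed within the scatter although the group on that carbon changed considerably. From that single step, compound 3 is expected to show no movement beyond the scatter, a step of a 1.0-fold lower number from compound 2 to compound 3 (0.01 log units; within the scatter). Compound 3 is therefore estimated at 150000 nM, with a range from 70000 nM to 320000 nM.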

Compound 3, half-maximal inhibitory concentration: 42000 nM
Compound 3: middle estimate off by 3.6-fold (0.55 log units), on the high side; measured number outside the range, below it.
By their numbers in this assay, from the lowest: compound 3; then compounds 1 and 2 (each within the scatter of the next).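

In this assay, the group on this aromatic carbon, next to the ring nitrogen, can move the number after all: 4-methoxyphenyl gives a 3.7-fold lower number from compound 2 to compound 3 (0.57 log units; beyond the scatter), and in place of naphthalen-2-yl it gives a 3.4-fold lower number from compound 1 to compound 3 (0.53 log units; beyond the scatter). The earlier exchange between naphthalen-2-yl and 3-(trifluoromethyl)phenyl had shown no separation, so the position is not indifferent to every change, although both new steps are only modest and compound 3 is the only one of the three that stands apart. No measurement shown accounts for this difference, and the exchange from compound 2 to compound 3 alters both the substituent on the phenyl ring and the numbered place it occupies, so the step cannot be assigned to either alone.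

The compounds shown leave open whether the methoxy group or its place on the ring matters, a question that 3-methoxyphenyl and 4-(trifluoromethyl)phenyl would address directly. They also leave open whether the lower number extends to other groups at the same place on the ring, such as 4-hydroxyphenyl, 4-ethoxyphenyl or 4-aminophenyl, or remains particular to 4-methoxyphenyl.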